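This account rests on a few compounds, and the source may have more. Where it says the series, first, only, none or still open, it means among the compounds named here.

Two compounds measured in an ADME assay on tissue (MIA PaCa-2 cells, Homo sapiens) for pharmacokinetics; a higher number here means that the compound lasts longer, a lower number that the compound disappears faster

compound 1 (`N[C@@H](CCC(=O)OC[C@H]1O[C@@H](n2cc(F)c(=O)[nH]c2=O)C[C@@H]1OC(=O)CC[C@H](N)C(=O)O)C(=O)O`) with 0.292 h
compound 2 (`N[C@@H](CC(=O)OC[C@H]1O[C@@H](n2cc(F)c(=O)[nH]c2=O)C[C@@H]1OC(=O)C[C@H](N)C(=O)O)C(=O)O`) with 0.188 h

These two values lie within the usual scatter of each other, so compound 1 stands level with compound 2 in this assay and no order can be drawn between them. Compound 3 (`N[C@@H](CCC(=O)O[C@H]1C[C@H](n2cc(F)c(=O)[nH]c2=O)O[C@@H]1CO)C(=O)O`) is reached from compound 1 by a single change, (hydrogen in place of (3-amino-3-carboxypropyl)carbonyl on an oxygen on a saturated carbon), namely hydrogen in place of (3-amino-3-carboxypropyl)carbonyl on an oxygen on a saturated carbon. A hydroxymethyl thus stands where compound 1 carries (((3-amino-3-carboxypropyl)carbonyl)oxy)methyl, and the second (3-amino-3-carboxypropyl)carbonyl group stays in place. Among the compounds with values here, no measured pair shows this kind of change, so the expectation rests on the structural difference alone and remains loose. A moderate rise in half-life is expected, with no change beyond the scatter also possible. The expected size of the move is a 2.1-fold higher number from compound 1 to compound 3 (0.31 log units; beyond the scatter) in this estimate. For compound 3 the estimated half-life is 0.6 h with an expected range from 0.25 h to 1.5 h in this measurement.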

Compound 3, half-life: 0.17 h
Compound 3: middle estimate off by 3.5-fold (0.55 log units), on the high side; measured number below the stated range.
By their numbers in this assay, from the lowest: compounds 3, 2 and 1 (each within the scatter of the next).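

In this assay, hydrogen in place of (3-amino-3-carboxypropyl)carbonyl on an oxygen on a saturated carbon gives a 1.7-fold lower number from compound 1 to compound 3 (0.23 log units; within the scatter), so this change leaves the half-life indistinguishable from that of compound 1. At this position, then, the hydroxymethyl of compound 3 and the (((3-amino-3-carboxypropyl)carbonyl)oxy)methyl of compound 1 stand level, and keeping only the second (3-amino-3-carboxypropyl)carbonyl group gives a reading that cannot be separated from that of the compound carrying both. No evidence accompanying these compounds bears on why the two stand level.

The compounds shown leave open how a different group on this oxygen would read in this assay, for example an acetyl, or a longer acyl chain carrying an amine but no carboxylic acid. Within the data shown here, they also leave open whether the (3-amino-3-carboxypropyl)carbonyl group that compound 3 keeps has any bearing on the half-life, since no compound here carries hydrogen in its place while leaving the rest of the core unchanged.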